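Swapping a Bromophenyl Amide for a Dimethoxyphenyl Amide

A few compounds are considered here, and "the series" means these few. Any claim that something is new, unique, unknown or untested is made for them only; others in the source may bear on it.

For the measured compounds named here, compound 3 `O=C(CN1CCN(c2nnc(Cc3ccncc3)c3ccccc23)CC1)Nc1cccc(Br)c1` gives 1530 nM in a functional assay on A549 cells (Homo sapiens) for cytotoxicity, read by MTT assay, with a stated time of 72 h (a higher number here means a weaker inhibitor, a lower number a stronger inhibitor), the lowest of the two numbers measured so far. Compound 1 `O=C(CN1CCN(c2nnc(Cc3ccncc3)c3ccccc23)CC1)Nc1ccc(Br)cc1` gives 2710 nM, and the step of a 1.8-fold lower number from compound 1 to compound 3 (0.25 log units; within the scatter) stays within the scatter. Compound 2 `COc1ccc(NC(=O)CN2CCN(c3nnc(Cc4ccccc4)c4ccccc34)CC2)cc1OC`, which also carries a 3,4-dimethoxyphenyl on its amide-type nitrogen but differs elsewhere, gives "not active" (no number reported) in this assay. Compound 4 `COc1ccc(NC(=O)CN2CCN(c3nnc(Cc4ccncc4)c4ccccc34)CC2)cc1OC` differs from compound 3 by 3,4-dimethoxyphenyl in place of 3-bromophenyl on an amide-type nitrogen. Going by the values given here, no measured step covers this exact change; the only measured step moves a bromine and changes little. Still, compound 4 is expected to be weaker, an estimated step of a 9.8-fold higher number from compound 3 to compound 4 (0.99 log units; beyond the scatter), partly because compound 2 gives "not active" (no number reported). Compound 4 is therefore estimated at 15000 nM, within a range of 4000 nM to 60000 nM, with a real chance that only a limit is reported.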

Compound 4, half-maximal inhibitory concentration: 26500 nM
Compound 4: the middle estimate sits 1.8-fold (0.25 log units) below what was measured; the measured number falls inside the stated range.
By their numbers in this assay, from the lowest: compounds 3 and 1 (each within the scatter of the next); then compound 4.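

Shifting the bromine stayed within the scatter, yet in this assay the 3,4-dimethoxyphenyl group brings a 17-fold higher number from compound 3 to compound 4 (1.24 log units; beyond the scatter) and a 9.8-fold higher number from compound 1 to compound 4 (0.99 log units; beyond the scatter) on the same amide-type nitrogen. The group at this position therefore clearly counts: both bromophenyl compounds hold a real lead over compound 4. Nothing measured here accounts for the drop. As far as these compounds go, whether the loss comes from the two methoxy groups together or from losing the bromine stays open. So does how a phenyl ring carrying a single methoxy, a chlorine or an amine would fare.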